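The source may report more compounds than this note shows. Statements on the series, on what has been measured and on what is new or still open speak of the compounds shown alone.

Measured compounds: compound 1 `CC1CCN(c2cc(C(F)(F)F)ccc2CNC(=O)C(C)c2ccc3c(c2)CCC3)CC1` with 96.4 nM; compound 2 `CC(C(=O)NCc1cc(C(F)(F)F)nn1-c1cccc(C(F)(F)F)c1)c1ccc2c(c1)CCC2` with 7.5 nM; compound 3 `CC(C(=O)NCc1cc(C(F)(F)F)nn1-c1ccc(Cl)cc1)c1ccc2c(c1)CCC2` with 45 nM.

In an assay on CHO-K1 cells for antagonist activity at transient receptor potential cation channel subfamily V member 1 (Homo sapiens), read by FLIPR (a higher number here means a weaker inhibitor, a lower number a stronger inhibitor), compound 3 gives 45 nM, the second highest of the three numbers: compound 1 gives 96.4 nM and compound 2 gives 7.5 nM. Compound 4 `CC(C(=O)NCc1cc(C(F)(F)F)nn1-c1ccc(C(F)(F)F)cc1)c1ccc2c(c1)CCC2` differs from compound 3 by trifluoromethyl in place of chloro on an aromatic carbon. Within the data shown here, no measured step changes only this group at this position; the one related step, a 6.0-fold higher number from compound 2 to compound 3 (0.78 log units; beyond the scatter), exchanged both the group and its position, so it bears on compound 4 only loosely. A moderate step toward a lower number is expected for compound 4, a 1.8-fold lower number from compound 3 to compound 4 (0.26 log units; within the scatter), because compound 2, carrying trifluoromethyl on this ring, gives 7.5 nM. Compound 4 is therefore estimated at 25 nM, within a range from 8 nM to 80 nM.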

Compound 4, inhibition constant: 51.3 nM
The estimate for compound 4 lay 2.1-fold (0.31 log units) below the measured number; low and high end bracket the measured number.
By their numbers in this assay, from the lowest: compound 2; then compounds 3, 4 and 1 (each within the scatter of the next, the first and the last beyond it).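

In this assay, with the group held para to a large group, trifluoromethyl in place of chloro leaves the number unchanged within the scatter (a 1.1-fold higher number from compound 3 to compound 4 (0.06 log units; within the scatter)). Moving the trifluoromethyl on the phenyl ring does separate the compounds (a 6.8-fold higher number from compound 2 to compound 4 (0.84 log units; beyond the scatter)), so trifluoromethyl on this ring does not by itself give the low number of compound 2. Nothing at hand explains either result. Still open, as far as these compounds go, is whether chloro, a methoxy group or a nitrile would match trifluoromethyl at the place it holds in compound 2.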